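Removing One Chloro From the Phenoxy Arm

This account rests on a few compounds, and the source may have more. Where it says the series, first, only, none or still open, it means among the compounds named here.

Compound 1 `CC(C)C[C@H](N)c1cc(C(F)(F)F)ccc1N1CCN(C(=O)C(C)Cc2ccc(Cl)cc2)CC1` gives 47 nM in an assay on HEK293 cells for displacement of a labelled ligand from Melanocortin receptor 4 (Homo sapiens); on this read-out lower numbers stand for stronger inhibition and higher numbers for weaker inhibition. Compound 2 `Cc1ccc(OCC(=O)N2CCN(c3ccc(C(F)(F)F)cc3[C@@H](N)CC(C)C)CC2)cc1` gives 4400 nM, and compound 3 `CC(C)C[C@H](N)c1cc(C(F)(F)F)ccc1N1CCN(C(=O)COc2cccc(Cl)c2Cl)CC1` gives 2500 nM. Compound 3 thus holds the second highest of the three numbers: the step of a 53-fold higher number from compound 1 to compound 3 (1.73 log units; beyond the scatter) is large, as is a 94-fold higher number from compound 1 to compound 2 (1.97 log units; beyond the scatter), while a 1.8-fold lower number from compound 2 to compound 3 (0.25 log units; within the scatter) stays within the scatter. Compound 4 `CC(C)C[C@H](N)c1cc(C(F)(F)F)ccc1N1CCN(C(=O)COc2cccc(Cl)c2)CC1` differs from compound 3 by hydrogen in place of chloro on an aromatic carbon. Within the data shown here, the one measured step that bears directly on this change is a 1.8-fold lower number from compound 2 to compound 3 (0.25 log units; within the scatter), where exchanging one aryl group on the phenoxy oxygen for another left the number essentially where it was; the two large steps concern replacement of the whole substituent on the carbonyl carbon and say nothing about a single chloro. Compound 4 is therefore expected to show no step beyond the scatter, so that a 1.2-fold higher number from compound 3 to compound 4 (0.08 log units; within the scatter) is estimated to be small. Compound 4 is expected to give about 3000 nM, within a range from 1200 nM to 8000 nM.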

Compound 4, inhibition constant: 2600 nM
Estimate against measurement, compound 4: 1.2-fold (0.06 log units) above; measured number inside the range.
By their numbers in this assay, from the lowest: compound 1; then compounds 3, 4 and 2 (each within the scatter of the next).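

Taking the chloro off the 2,3-dichlorophenyl group to leave 3-chlorophenyl gives a 1.0-fold higher number from compound 3 to compound 4 (0.02 log units; within the scatter), so in this assay this single chloro leaves no mark on the number. With a 1.7-fold lower number from compound 2 to compound 4 (0.23 log units; within the scatter) as well, the 4-methylphenyl, 2,3-dichlorophenyl and 3-chlorophenyl groups on the oxygen cannot be told apart, while the gap to the 1-(4-chlorobenzyl)ethyl group stays large at a 55-fold higher number from compound 1 to compound 4 (1.74 log units; beyond the scatter). The data shown offer no measurement that would account for either finding.

From the compounds shown here alone, whether a fluoro or a methoxy on this aromatic carbon would read the same remains open, as does the effect of also replacing the remaining chloro with hydrogen. Also open, going by these compounds, is whether a methyl on the saturated carbon of the (3-chlorophenoxy)methyl group, or a longer chain there, would narrow the gap to compound 1.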